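This account rests on a few compounds, and the source may have more. Where it says the series, first, only, none or still open, it means among the compounds named here.

Compound 2 `CCCCS(=O)(=O)Nc1cc(-c2ccc3ncnc(Nc4ccc(OCCO)nc4)c3c2)cnc1OC` gives > 20000 nM in a functional assay on MCF7 cells (Homo sapiens) for antiproliferative activity, read by sulforhodamine B assay, with a stated time of 72 h (a lower number here means a stronger inhibitor, a higher number a weaker inhibitor), and this reading is a limit of the assay, not a number. Two relatives give numbers on the same read-out. Compound 3 `COc1ncc(-c2ccc3ncnc(Nc4ccc(OCCO)c(F)c4)c3c2)cc1NS(=O)(=O)c1ccc(F)cc1F` gives 4820 nM in this assay as its measured value. Compound 1 `COc1ncc(-c2ccc3ncnc(Nc4cnn(CCC(=O)O)c4)c3c2)cc1NS(C)(=O)=O` gives 560 nM in this assay as its measured value.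

Compound 4 `COc1ncc(-c2ccc3ncnc(Nc4ccc(OCCO)nc4)c3c2)cc1NS(C)(=O)=O` departs from compound 2 at one place: hydrogen in place of propyl on a saturated chain carbon bound to a sulfonyl sulfur with hydrogen in place of propyl on a saturated chain carbon bound to a sulfonyl sulfur, so that butylsulfonyl becomes methylsulfonyl. Within the data shown here, no measured pair isolates this change, and the limit on compound 2 leaves its true value open.

The only indirect support comes from compound 1, which carries the same methanesulfonamido group and gives 560 nM in spite of differing from compound 4 elsewhere. On that basis, a step beyond the scatter towards a stronger inhibitor is expected, though its size is poorly fixed. The expected change is an at least 6.6-fold lower number from compound 2 to compound 4 (0.82 log units; beyond the scatter) as an estimate and no more. For compound 4 the estimated value is 3000 nM with an expected range from 600 nM to 20000 nM in this assay pending measurement.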

Compound 4, half-maximal inhibitory concentration: 3080 nM
For compound 4 the middle estimate is 1.0-fold (0.01 log units) below the measured one, within the range that was stated.
By their numbers in this assay, from the lowest: compound 1; then compounds 4 and 3 (each within the scatter of the next). At a limit, above all of these: compound 2.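

In this assay, among these compounds, the pair gives the first reading of a change on a saturated chain carbon bound to a sulfonyl sulfur: an at least 6.4-fold lower number from compound 2 to compound 4 (0.81 log units; beyond the scatter), with butylsulfonyl becoming methylsulfonyl while the 6-(2-hydroxyethoxy)pyridin-3-yl group stays in place. Compound 2 stands at a limit of the assay, not a number, so this step has a bound but no fixed size: the limit of > 20000 nM in this assay, at which 1 of the 4 values shown sits.

With the methanesulfonamido group held constant, the second pair gives a 5.5-fold higher number from compound 1 to compound 4 (0.74 log units; beyond the scatter), with 6-(2-hydroxyethoxy)pyridin-3-yl in place of 1-(2-carboxyethyl)-1H-pyrazol-4-yl on a nitrogen on an aromatic ring, so the number in this series also moves beyond the scatter with the group at that second place.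

The compounds shown leave open how an ethyl or a propyl chain on the sulfonyl sulfur would read against methyl and butyl, and what an amine or a carboxylic acid at the end of that chain would do. Going by these compounds, it also remains open whether the 1-(2-carboxyethyl)-1H-pyrazol-4-yl group would give a measurable number when paired with butylsulfonyl rather than methylsulfonyl.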